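Chain lengthening on a benzoylated threonine amide

The compounds below may be only part of what the source reports. "The series", "measured", "known", "first", "only" and "open" are said of these compounds alone.

Measured compounds:
compound 1, `CCCCCCCCCCCCCCNC(=O)[C@@H](N)[C@@H](C)O`, 18700 nM
compound 2, `CCCCCCCCCCCCNC(=O)[C@@H](NC(=O)c1ccccc1)[C@@H](C)O`, 200000 nM

The study examines cytotoxicity in a functional assay on SW-620 cells (Homo sapiens) for cytotoxicity, read by MTT assay, with a stated time of 48 h; a higher number here means a weaker inhibitor, a lower number a stronger inhibitor. Compound 1 gives 18700 nM in this assay. Compound 2 gives 200000 nM in this assay, the higher of the two numbers, and its gap to compound 1 lies beyond the usual scatter; the two compounds differ in more than one place, so the numbers alone are reported without a single change to pin them on.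

Compound 3, `CCCCCCCCCCCCCCNC(=O)[C@@H](NC(=O)c1ccccc1)[C@@H](C)O`, has not yet been measured. It differs from compound 2 by ethyl in place of hydrogen on a saturated chain carbon, ten or more bonds along the chain from an amide-type nitrogen, the rest of the structure kept as it stands in compound 2.

Among the measured compounds shown here, no measured pair shows this change on its own, so the size of the step is open. Because compound 1 gives 18700 nM and carries the same chain length as compound 3, a modest move toward a lower number is expected in this assay rather than none, while a result within the scatter of compound 2 remains plausible. The estimated step is a 2.0-fold lower number from compound 2 to compound 3 (0.30 log units; within the scatter). Compound 3 is expected to give 100000 nM in this assay, in a range from 30000 nM to 300000 nM.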

Compound 3, half-maximal inhibitory concentration: 200000 nM
For compound 3 the middle estimate is 2.0-fold (0.30 log units) below the measured one, and the stated range covers the measured number.
By their numbers in this assay, from the lowest: compound 1; then compounds 2 and 3 (each within the scatter of the next).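

In this assay, ethyl in place of hydrogen on a saturated chain carbon, ten or more bonds along the chain from an amide-type nitrogen, gives no change at the digits printed from compound 2 to compound 3 (within the scatter), so this lengthening of the chain does not separate the two benzoylated compounds. Among the compounds shown here, compound 3 also provides the first comparison in which only the amine nitrogen changes: benzoyl in place of hydrogen on that nitrogen gives an 11-fold higher number from compound 1 to compound 3 (1.03 log units; beyond the scatter), a large step and the only one of the two single changes that lies beyond the scatter. Nothing among the data shown explains either step.

Going by these compounds, it remains open whether a longer chain on the benzoylated compounds would leave the number just as flat, or whether the same ethyl change would also have no effect on a chain carried by the free amine. Also open, on these data alone, is how an acetyl group or a smaller amide on the amine nitrogen would compare with benzoyl and with the free amine.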